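This account rests on a few compounds, and the source may have more. Where it says the series, first, only, none or still open, it means among the compounds named here.

Measured so far in an ADME assay on microsomes from liver (Rattus norvegicus) for metabolic stability, with a stated time of 10 min; a lower number here means that less of the compound is left, a higher number that more of the compound is left:
compound 1 `CCOc1nc(C)c(Nc2nc(Cl)cn([C@H](C)C3CC3)c2=O)cc1C` gives 93%
compound 2 `COc1nc(C)c(Nc2nc(Cl)cn([C@H](C)C3CC3)c2=O)c(OC)n1` gives 86%

The numbers for compound 2 and compound 1 lie within the usual scatter of each other. Compound 3 `COC[C@H](C1CC1)n1cc(Cl)nc(Nc2c(C)nc(OC)nc2OC)c1=O` carries one change from compound 2, methoxy in place of hydrogen on a saturated chain carbon, two bonds along the chain from an aromatic nitrogen and a saturated ring carbon in words methoxy in place of hydrogen on a saturated chain carbon, two bonds along the chain from an aromatic nitrogen and a saturated ring carbon. Going by the values given here, no measured pair shows this change, so the expectation has no direct precedent. A modest fall of about the size of the scatter is expected, estimated as a number 8 percentage points lower from compound 2 to compound 3 (within the scatter) in this assay here. Compound 3 is estimated at 78% with 60% to 93% as the expected range.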

Compound 3, percent of the compound remaining: 45%
Estimate against measurement, compound 3: 33 percentage points above, and the stated range ends above it.
By their numbers in this assay, from the lowest: compound 3; then compounds 2 and 1 (each within the scatter of the next).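

In this assay, the saturated chain carbon two bonds along the chain from an aromatic nitrogen and a saturated ring carbon proves sensitive: methoxy in place of hydrogen there gives a number 41 percentage points lower from compound 2 to compound 3 (beyond the scatter) and turns 1-cyclopropylethyl into 1-cyclopropyl-2-methoxyethyl. Compounds 1 and 2 share the 1-cyclopropylethyl group, so they could not show this. Nothing measured here accounts for the fall. This single step cannot separate the oxygen from the added length. As far as these compounds go, how a longer chain without oxygen, or an amine, would behave at this carbon remains open.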